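Amide substituent swap in a pyrimidine ether series

This account rests on a few compounds, and the source may have more. Where it says the series, first, only, none or still open, it means among the compounds named here.

Measured compounds:
compound 1, `Cc1cccc(Oc2ccnc(N3CCC[C@H]3C(=O)NCc3cccnc3)n2)c1`, 6%
compound 2, `COC[C@@H]1CCCN1C(=O)[C@@H]1CCCN1c1cc(Nc2cccc(OC)c2)nc(N)n1`, 0%

Both numbers come from an assay on isolated protein for inhibition of tyrosine-protein kinase ZAP-70 (Homo sapiens), read by HTRF, tested at 10 uM; a higher number here means more inhibition at the concentration tested (going by the name of the read-out), a lower number less inhibition. Compound 1 gives 6%, the higher of the two figures, and compound 2 gives 0%; the gap between them is within the scatter, so neither compound can be set above the other. Both sit near the floor of the read-out.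

Compound 3, `COC(=O)C(CO)NC(=O)[C@@H]1CCCN1c1nccc(Oc2cccc(C)c2)n1`, has not been measured in this assay. It differs from compound 1 in one place: 2-hydroxy-1-(methoxycarbonyl)ethyl in place of (pyridin-3-yl)methyl on an amide-type nitrogen. The rest of compound 1 is kept.

Going by the values given here, no step between measured compounds is available to calibrate this change. With compound 1 already near the floor and compound 2 equally low, the expected step of a number 1 percentage points lower from compound 1 to compound 3 (within the scatter) is none beyond the scatter. Compound 3 is therefore estimated at 5% in this assay, with a range from -8% to 20%.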

Compound 3, a percentage reported as inhibition, at one concentration (the size of the read-out at that concentration, not a potency): 0%
Estimate against measurement, compound 3: 5 percentage points above; the range from low to high includes it.
By their numbers in this assay, from the lowest: compounds 2, 3 and 1 (each within the scatter of the next).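

In this assay, 2-hydroxy-1-(methoxycarbonyl)ethyl in place of (pyridin-3-yl)methyl on the amide-type nitrogen gives a number 6 percentage points lower from compound 1 to compound 3 (within the scatter), the first one-place comparison available at this position. An open-chain group with no ring and a six-membered aromatic ring with one hetero atom therefore cannot be told apart here, even though the two groups differ in their counts of hydrogen-bond donors and acceptors. No measurement bears on this outcome.

With compound 1 and compound 3 both near the floor of the read-out, the comparison cannot show whether this nitrogen is insensitive to its substituent or whether the shared core simply gives too little signal for any difference to appear. From the compounds shown here alone, whether a carboxylic acid in place of the methyl ester, or an aminoethyl chain on the same nitrogen, would lift the read-out remains open.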